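This account rests on a few compounds, and the source may have more. Where it says the series, first, only, none or still open, it means among the compounds named here.

Among the measured compounds shown here, in an ADME assay on CEM-SS cells (Homo sapiens) for cytotoxicity, read by XTT assay, with a stated time of 6 days (a higher number here means that more compound is tolerated, a lower number that less compound is tolerated), compound 2 `CCCC(=O)OCSc1ccccc1C(=O)NCCCCCCC(N)=O` gives 10.4 uM, the only exact number so far. Compound 1 `CCCC(=O)OCSc1ccccc1C(=O)NCCC(N)=O` gives > 100 uM, which is a limit of the assay. Compound 3 `CCCC(=O)OCSc1ccccc1C(=O)NCCCCNC(C)=O` differs from compound 2 by acetamido in place of 2-carbamoylethyl on a saturated chain carbon, four bonds along the chain from an amide-type nitrogen: acetamido in place of 2-carbamoylethyl, on a saturated chain carbon, four bonds along the chain from an amide-type nitrogen. For the measured compounds named here, the only measured guide is an at least 9.6-fold lower number from compound 1 to compound 2 (0.98 log units; beyond the scatter), a step beyond the scatter that came with 4-carbamoylbutyl replacing carbamoyl. A partial reversal of that step is expected here. The expected move is a 2.4-fold higher number from compound 2 to compound 3 (0.38 log units; beyond the scatter), toward more compound being tolerated. Compound 3 is estimated at 25 uM, within a range of 9 uM to 80 uM.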

Compound 3, half-maximal toxic concentration: 17.4 uM
Compound 3: the middle estimate sits 1.4-fold (0.16 log units) above what was measured, and the stated range covers the measured number.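

In this assay, acetamido in place of 2-carbamoylethyl gives a 1.7-fold higher number from compound 2 to compound 3 (0.22 log units; within the scatter) and so shows no readable change at this place on the chain. Putting 2-acetamidoethyl in place of carbamoyl gives an at least 5.7-fold lower number from compound 1 to compound 3 (0.75 log units; beyond the scatter) and so the fall seen earlier does not belong to the 4-carbamoylbutyl group alone. The size of that step is only a bound, because the value for compound 1 is a limit: the limit of > 100 uM in this assay, at which 1 of the 3 values shown sits.

Left open is whether an amine or a carboxylic acid in place of acetamido would keep the number at this level. Also open, going by these compounds, is what a longer chain would do.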